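The source may hold more compounds than are shown below. What is called first, only, known or untested is meant among the compounds shown, and "the series" means these compounds.

Compound 1 `O=S(=O)(NCCNC(=S)Nc1cccc(Cl)c1)c1ccc(-c2ccccc2OCc2ccccc2)s1`: 8400 nM
Compound 2 `O=C(NCCNS(=O)(=O)c1ccc(-c2ccccc2OCc2ccccc2)s1)Nc1cc(Cl)cc(Cl)c1`: > 20000 nM

In a functional assay on HeLa cells (Homo sapiens) for inhibition, read by CCK-8 assay, with a stated time of 48 h (a lower number here means a stronger inhibitor, a higher number a weaker inhibitor), compound 1 gives 8400 nM. For compound 2 only a limit is known, > 20000 nM, so its place on the scale is a boundary rather than a number. Going by the values given here, the single measured step, an at least 2.3-fold higher number from compound 1 to compound 2 (0.37 log units; beyond the scatter), changed the group on an amine nitrogen, and its size is known only as a lower bound because of the limit of > 20000 nM in this assay, at which 1 of the 2 values shown sits.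

Compound 3 `O=[N+]([O-])c1ccc(NC(=S)NCCNS(=O)(=O)c2ccc(-c3ccccc3OCc3ccccc3)s2)cc1` differs from compound 2 at the same amine nitrogen: a group of 12 heavy atoms (7 carbon, 2 nitrogen, 2 oxygen, 1 sulfur; one six-membered aromatic ring of carbon only) in place of a group of 11 heavy atoms (7 carbon, 1 nitrogen, 1 oxygen, 2 chlorine; one six-membered aromatic ring of carbon only), on an amine nitrogen. The entering group shares with the group of compound 1 a sulfur in place of the oxygen that compound 2 carries, while its aromatic ring bears a different substituent from either measured compound. Among the compounds with values here, the one measured step bears on this change only indirectly, since it moved in the other direction and was cut off at the limit; it suggests that the oxygen-bearing group of compound 2 sat at the weak end. A return toward the level of compound 1 is therefore expected, with wide uncertainty, giving an expected step of an at least 2.0-fold lower number from compound 2 to compound 3 (0.30 log units; that floor lies within the scatter). Compound 3 is estimated at 10000 nM, with a range from 3000 nM to 30000 nM.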

Compound 3, half-maximal inhibitory concentration: 7100 nM
Compound 3: middle estimate off by 1.4-fold (0.15 log units), on the high side, and the stated range covers the measured number.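

The step of a 1.2-fold lower number from compound 1 to compound 3 (0.07 log units; within the scatter) lies within the scatter in this assay, so among the two compounds that carry sulfur, 4-nitrophenyl and 3-chlorophenyl on the amide-type nitrogen cannot be told apart. The other new step, an at least 2.8-fold lower number from compound 2 to compound 3 (0.44 log units; beyond the scatter), lies beyond the scatter and shows that the weak reading of compound 2 is not shared by every group tried on this amine nitrogen. Compound 2 has a limit rather than a number, so this step is known only as a lower bound: the limit of > 20000 nM in this assay, at which 1 of the 3 values shown sits.

Compound 2 differs from compound 1 and compound 3 both in having oxygen where they have sulfur and in its ring, the 3,5-dichlorophenyl group, and the compounds shown do not separate these two changes. Going by these compounds, how a phenyl ring bearing a methoxy group or a carboxylic acid would read at this position also remains open, as does the effect of a longer chain on the amine nitrogen.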